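Sulfonyl in place of carbamoyl on the shared core

A few compounds are considered here, and "the series" means these few. Any claim that something is new, unique, unknown or untested is made for them only; others in the source may bear on it.

Going by the values given here, compound 1 `Cn1c(=O)c(C(=O)Nc2ccc(F)cc2F)cc2cnc(Nc3ccc4[nH]ccc4c3)nc21` is the weaker of the two compounds measured so far: in a functional assay on K562 cells (Homo sapiens) for inhibition, read by trypan blue exclusion, with a stated time of 72 h (a higher number here means a weaker inhibitor, a lower number a stronger inhibitor), compound 1 gives 5000 nM, while compound 2 `Cn1ccc2cc(Nc3ncc4cc(S(=O)(=O)c5ccc(F)cc5F)c(=O)n(C)c4n3)ccc21` gives 750 nM, a gap that lies beyond the scatter. Among the compounds with values here, compound 2 differs from compound 1 in more than one place, so no single-change step is available.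

Compound 3 `Cn1c(=O)c(S(=O)(=O)c2ccc(Br)cc2)cc2cnc(Nc3ccc4[nH]ccc4c3)nc21` is the next compound for this assay. It differs from compound 1 in one place: (4-bromophenyl)sulfonyl in place of (2,4-difluorophenyl)carbamoyl on an aromatic carbon. Within the data shown here, no step of this kind has been measured. The two values shown hint that a sulfonyl-bearing compound can come in lower, and the expected step from compound 1 to compound 3 is therefore estimated at a 3.3-fold lower number from compound 1 to compound 3 (0.52 log units; beyond the scatter), a lowering of the number beyond the scatter, though the support for it is thin. For compound 3 the estimate in this assay is 1500 nM, with a range from 400 nM to 5000 nM.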

Compound 3, half-maximal inhibitory concentration: 5000 nM
The estimate for compound 3 lay 3.3-fold (0.52 log units) below the measured number, within the range that was stated.
By their numbers in this assay, from the lowest: compound 2; then compounds 1 and 3 (each within the scatter of the next).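

In this assay, going by these compounds alone, the first single-change step at this aromatic carbon reads no change at the digits printed from compound 1 to compound 3 (within the scatter), so (4-bromophenyl)sulfonyl and (2,4-difluorophenyl)carbamoyl cannot be told apart here, although the entering group has 0 hydrogen-bond donors against 1 in the group that leaves. With this aryl group, then, a sulfonyl at this position does not by itself bring the number down, and the earlier hint from a pair differing in more than one place does not hold for this step. No measurement here bears on why the two groups read alike.

The step swaps the linking group and the halogens on the phenyl ring together, so their separate contributions, which could also cancel, remain unresolved. Also open, going by these compounds, is how an amine, a carboxylic acid or a longer chain on this aromatic carbon would read.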